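Bromo-hydroxyphenyl Replaces Methoxyphenyl on the Benzylidene Arm

The source may report more compounds than this note shows. Statements on the series, on what has been measured and on what is new or still open speak of the compounds shown alone.

compound 1 `CCOC(=O)C1=C(Nc2ccccc2)S/C(=C\c2ccccc2)C1=O` 42.9%
compound 2 `CCOC(=O)C1=C(Nc2ccccc2)S/C(=C\c2ccc(OC)cc2)C1=O` 9.6%

In a functional assay on K562 cells (Homo sapiens) for inhibition, read by MTT assay, with a stated time of 72 h, tested at 10 uM (a lower number here means less inhibition, a higher number more inhibition at the concentration tested (going by the name of the read-out)), compound 2 gives the lowest of the two numbers; its nearest neighbour is compound 1, with the step of a number 33.3 percentage points lower from compound 1 to compound 2 (beyond the scatter). Compound 3 `CCOC(=O)C1=C(Nc2ccccc2)S/C(=C\c2ccc(Br)c(O)c2)C1=O` carries the change (4-bromo-3-hydroxyphenyl in place of 4-methoxyphenyl on a double-bonded chain carbon bound to a double-bonded ring carbon). No measured step tests this swap directly; the only step shown, from hydrogen to methoxy, bears on it indirectly since the methoxy group that leaves was tied to that large drop. Among the compounds with values here, a moderate rise is therefore expected, a number 15.4 percentage points higher from compound 2 to compound 3 (beyond the scatter), though the bromine and hydroxyl that enter have no precedent here. Compound 3 is estimated at 25%, within 5% to 50%.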

Compound 3, a percentage reported as inhibition, at one concentration (the size of the read-out at that concentration, not a potency): 22%
Compound 3: the middle estimate sits 3 percentage points above what was measured, and the stated range covers the measured number.
By their numbers in this assay, from the lowest: compound 2; then compound 3; then compound 1.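

In this assay, 4-bromo-3-hydroxyphenyl in place of 4-methoxyphenyl brings a partial recovery at this position (a number 12.4 percentage points higher from compound 2 to compound 3 (beyond the scatter)), so not every substituted ring here sits as low as the methoxy compound. Against plain phenyl the same group still falls short (a number 20.9 percentage points lower from compound 1 to compound 3 (beyond the scatter)), which leaves the unsubstituted ring ahead of both substituted ones. Nothing at hand explains these differences between the groups. The compounds shown do not separate the bromine from the hydroxyl, since both enter together. On these data alone, whether 3-hydroxyphenyl alone, 4-bromophenyl alone or an aminophenyl would match compound 1 stays open.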